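Methoxy for vinyl at the chain carbon: cytotoxicity notes

The compounds below may be only part of what the source reports. "The series", "measured", "known", "first", "only" and "open" are said of these compounds alone.

Compound 3 `C=CCN(c1ccnc(Nc2ccc(C#N)cc2)n1)c1c(F)cc(-c2ccc(C#N)cc2)cc1F` gives 249000 nM in an ADME assay on MT4 cells (Homo sapiens) for cytotoxicity, read by MTT assay, with a stated time of 5 days (on this read-out lower numbers stand for higher toxicity in this test and higher numbers for lower toxicity in this test), the highest of the three numbers in hand. Compound 1 `CN(c1ccnc(Nc2ccc(C#N)cc2)n1)c1c(F)cc(-c2ccc(C#N)cc2)cc1F` gives 148000 nM in this assay, and the step of a 1.7-fold higher number from compound 1 to compound 3 (0.23 log units; within the scatter) stays within the scatter. Compound 2 `N#Cc1ccc(Nc2nccc(N(CC(O)CO)c3c(F)cc(-c4ccc(C#N)cc4)cc3F)n2)cc1` gives 19500 nM in this assay; the steps of a 7.6-fold lower number from compound 1 to compound 2 (0.88 log units; beyond the scatter) and a 13-fold higher number from compound 2 to compound 3 (1.11 log units; beyond the scatter) are the only ones beyond the scatter, and both involve the 1,2-dihydroxyethyl group. Compound 4 `COCN(c1ccnc(Nc2ccc(C#N)cc2)n1)c1c(F)cc(-c2ccc(C#N)cc2)cc1F` differs from compound 3 by methoxy in place of vinyl on a saturated chain carbon bound to a nitrogen on an aromatic ring. Going by the values given here, no measured step exchanges vinyl for methoxy directly. The step of a 1.7-fold higher number from compound 1 to compound 3 (0.23 log units; within the scatter) shows that placing vinyl on this chain carbon leaves the number within the scatter, while a 7.6-fold lower number from compound 1 to compound 2 (0.88 log units; beyond the scatter) ties the only clear drop to the 1,2-dihydroxyethyl group. Methoxy brings no donor and one acceptor, so the expected step of a 1.4-fold lower number from compound 3 to compound 4 (0.14 log units; within the scatter) is none beyond the scatter. The estimate for compound 4 in this assay is 180000 nM, expected to lie between 70000 nM and 400000 nM.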

Compound 4, half-maximal cytotoxic concentration: 238000 nM
Beside the measured number, compound 4's estimate is 1.3-fold (0.12 log units) below it; measured number inside the range.
By their numbers in this assay, from the lowest: compound 2; then compounds 1, 4 and 3 (each within the scatter of the next).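

In this assay methoxy on a saturated chain carbon bound to a nitrogen on an aromatic ring stands level with vinyl (a 1.0-fold lower number from compound 3 to compound 4 (0.02 log units; within the scatter)) and with hydrogen (a 1.6-fold higher number from compound 1 to compound 4 (0.21 log units; within the scatter)), so a group with an oxygen at this place does not in itself go with the clear drop. The drop stays with the 1,2-dihydroxyethyl group, which is also clearly apart from methoxy (a 12-fold higher number from compound 2 to compound 4 (1.09 log units; beyond the scatter)), and among these four compounds only compound 2 carries it. Nothing at hand explains why the two oxygen-bearing groups part in this way.

On these data alone, whether a single hydroxy group on the chain is enough for the drop seen with 1,2-dihydroxyethyl remains open. As far as these compounds go, an amine or a carboxylic acid at this chain carbon, or a longer chain, also remains open.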